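A few compounds are considered here, and "the series" means these few. Any claim that something is new, unique, unknown or untested is made for them only; others in the source may bear on it.

Of the compounds shown here, three sharing one core have been measured in a functional assay on the whole organism for inhibition, with Rattus norvegicus as the target, read by paw edema, at a dose of 100 mg/kg by the oral route; a lower number here means less inhibition, a higher number more inhibition at the dose given (going by the name of the read-out). Compound 1 `CCCCNC(=O)c1c(O)c2cccnc2n(-c2ccccc2)c1=O` gives 12.8%, compound 2 `COc1ccc(NC(=O)c2c(O)c3cccnc3n(-c3ccccc3)c2=O)cc1` gives 0.3%, and compound 3 `Cc1cccc(NC(=O)c2c(O)c3cccnc3n(-c3ccccc3)c2=O)c1` gives 14.2%, the highest of the three numbers; its step to compound 1 lies within the scatter, while a number 13.9 percentage points higher from compound 2 to compound 3 (beyond the scatter) lies beyond it. Compound 4 `O=C(Nc1cccc(Cl)c1)c1c(O)c2cccnc2n(-c2ccccc2)c1=O` has not yet been tested. It differs from compound 3 by chloro in place of methyl on an aromatic carbon. Within the data shown here, no measured step swaps one group for another on that aromatic ring, but a number 1.4 percentage points higher from compound 1 to compound 3 (within the scatter) and a number 13.9 percentage points higher from compound 2 to compound 3 (beyond the scatter) show that changing the amide substituent moves the read-out only modestly. Compound 4 is therefore expected to land near compound 3, estimated at 15% with a range from 4% to 28%, a step of a number 0.8 percentage points higher from compound 3 to compound 4 (within the scatter).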

Compound 4, a percentage reported as inhibition, in the whole organism at one dose (the size of the read-out at that dose, not a potency): 7.6%
For compound 4 the middle estimate is 7.4 percentage points above the measured one; low and high end bracket the measured number.
By their numbers in this assay, from the lowest: compounds 2, 4, 1 and 3 (each within the scatter of the next, the first and the last beyond it).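

In this assay the step of chloro in place of methyl on this aromatic carbon, meta to a large group, is a number 6.6 percentage points lower from compound 3 to compound 4 (within the scatter) and so does not separate the two groups. Compound 4 also stays within the scatter of both other amides, with a number 7.3 percentage points higher from compound 2 to compound 4 (within the scatter) and a number 5.2 percentage points lower from compound 1 to compound 4 (within the scatter) even though compound 2 and compound 3 stand apart. No measurement shown gives a reason for these numbers. From the compounds shown here alone, whether an amine, a carboxylic acid or a longer chain on this carbon would give a step beyond the scatter remains open.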